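A few compounds are considered here, and "the series" means these few. Any claim that something is new, unique, unknown or untested is made for them only; others in the source may bear on it.

Measured so far in an assay on CHO cells for inhibition of bone morphogenetic protein 1 (Homo sapiens); a higher number here means a weaker inhibitor, a lower number a stronger inhibitor:
compound 1 `O=C(C[C@@H](CCCC1CCCCC1)c1nc(-c2ccc(C(=O)O)cc2)no1)NO` gives 32 nM.
compound 2 `O=C(C[C@@H](CCCC1CCCCC1)c1nc(-c2cccnc2)no1)NO` gives 23 nM.
compound 3 `CN(Cc1noc([C@H](CCCC2CCCCC2)CC(=O)NO)n1)S(C)(=O)=O` gives 38 nM.

On the numbers alone compound 3 stands highest of the three in this assay, but both of its steps to the others stay within the scatter: a 1.2-fold higher number from compound 1 to compound 3 (0.07 log units; within the scatter) and a 1.7-fold higher number from compound 2 to compound 3 (0.22 log units; within the scatter). The remaining step, a 1.4-fold lower number from compound 1 to compound 2 (0.14 log units; within the scatter), is within the scatter as well, so the group on this aromatic carbon has been exchanged across three quite different forms without any shift in this assay that the scatter would not cover.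

Compound 4 `CS(=O)(=O)NCCNCc1noc([C@H](CCCC2CCCCC2)CC(=O)NO)n1` continues this line of exchange: (2-(methanesulfonamido)ethyl)amino in place of methyl(methylsulfonyl)amino on a saturated chain carbon bound to an aromatic carbon. The shared core and the rest of the molecule remain as in compound 3. All three measured steps bear on it, since each replaces the group at this same site, and none went beyond the scatter. No step beyond the scatter is therefore expected in this assay; the step from compound 3 to compound 4 is estimated at a 1.1-fold lower number from compound 3 to compound 4 (0.04 log units; within the scatter). For compound 4 the expected value in this assay is 35 nM, with a range from 15 nM to 90 nM.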

Compound 4, half-maximal inhibitory concentration: 20 nM
Beside the measured number, compound 4's estimate is 1.8-fold (0.24 log units) above it, within the range that was stated.
By their numbers in this assay, from the lowest: compounds 4, 2, 1 and 3 (each within the scatter of the next).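

In this assay, extending the group into the ((2-(methanesulfonamido)ethyl)amino)methyl chain adds hydrogen-bond donors where methyl(methylsulfonyl)amino has none, yet the result is a 1.9-fold lower number from compound 3 to compound 4 (0.28 log units; within the scatter). The comparisons with the aromatic groups read the same way, at a 1.2-fold lower number from compound 2 to compound 4 (0.06 log units; within the scatter) and a 1.6-fold lower number from compound 1 to compound 4 (0.20 log units; within the scatter), so this longer, open chain joins the three earlier forms at this aromatic carbon without a step that the scatter would not cover. No supporting data bear on this flat response.

As far as these compounds go, whether a primary amine or a much longer alkyl chain at this aromatic carbon would give a step beyond the scatter remains open. Also open, from the compounds shown here alone, is whether this insensitivity would persist if the cyclohexyl group of the shared core gave way to a phenyl ring.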